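Moving the nitrile: from compound 1 to compound 3

The compounds below may be only part of what the source reports. "The series", "measured", "known", "first", "only" and "open" are said of these compounds alone.

- Compound 1 `COc1cc2c(Nc3ccc(C#N)cc3)ncnc2cc1OCCCN1CCC(C)CC1` gives 7900 nM
- Compound 2 `COc1cc2c(Nc3ccc(C#N)cc3)ncnc2cc1OCCCN1CCCCC1CCO` gives > 100000 nM, which is a limit

Within the data shown here, in a functional assay on SH-SY5Y cells (Homo sapiens) for antiproliferative activity, read by MTT assay, with a stated time of 72 h (on this read-out higher numbers stand for weaker inhibition and lower numbers for stronger inhibition), compound 1 holds the only actual number so far. Compound 3 `COc1cc2c(Nc3cccc(C#N)c3)ncnc2cc1OCCCN1CCC(C)CC1` has the same atoms as compound 1, joined differently: 3-cyanophenyl in place of 4-cyanophenyl on a nitrogen on an aromatic ring, with 3-cyanophenyl in place of 4-cyanophenyl on a nitrogen on an aromatic ring. Among the measured compounds shown here, the only measured step, an at least 12-fold higher number from compound 1 to compound 2 (1.10 log units; beyond the scatter), was large but changed the other end of the molecule, so it offers no direct guide here. The expected change, a 1.0-fold higher number from compound 1 to compound 3 (0.01 log units; within the scatter), is therefore none beyond the scatter. Compound 3 is estimated at 8000 nM, with 2500 nM to 30000 nM as the expected range.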

Compound 3, half-maximal inhibitory concentration: 7330 nM
Compound 3: middle estimate off by 1.1-fold (0.04 log units), on the high side; measured number inside the range.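

In this assay, exchanging 4-cyanophenyl for 3-cyanophenyl on the nitrogen gives a 1.1-fold lower number from compound 1 to compound 3 (0.03 log units; within the scatter) and so shows that, at this end of the molecule, the two placements of the nitrile read alike. Among these compounds, the earlier step had changed only the other end, so this is the first reading of the cyanophenyl group. Nothing shown here bears on why the two placements read alike.

Still open, as far as these compounds go, is whether 2-cyanophenyl would read the same. From the compounds shown here alone, it is also open whether an amine or a carboxylic acid could replace the nitrile on this ring.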